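Hydroxy to methoxy: cytotoxicity notes on four amides

A few compounds are considered here, and "the series" means these few. Any claim that something is new, unique, unknown or untested is made for them only; others in the source may bear on it.

Measured compounds in an ADME assay on Vero cells (Chlorocebus sabaeus) for cytotoxicity, read by fluorescence, with a stated time of 4 days; a higher number here means a weaker inhibitor, a lower number a stronger inhibitor:
compound 1 `COc1ccc(O)c(C(=O)NCC(C)(C)CC2=C(O)C(=O)c3ccccc3C2=O)c1` gives 31100 nM
compound 2 `COc1cc(C(=O)NCC(C)(C)CC2=C(O)C(=O)c3ccccc3C2=O)c(O)c2ccccc12` gives 15800 nM
compound 3 `COc1ccc(OC)c(C(=O)NCC(C)(C)CC2=C(O)C(=O)c3ccccc3C2=O)c1` gives 89100 nM

Compound 1 and compound 3 differ by methyl in place of hydrogen on an oxygen on an aromatic ring and the step was a 2.9-fold higher number from compound 1 to compound 3 (0.46 log units; beyond the scatter). The difference between the cores of compound 1 and compound 2 is not broken down here; their values lie within the scatter of each other, so no order is drawn. Compound 4 `COc1cc(C(=O)NCC(C)(C)CC2=C(O)C(=O)c3ccccc3C2=O)c(OC)c2ccccc12` is not yet measured. It differs from compound 2 by methyl in place of hydrogen on an oxygen on an aromatic ring, the same change as from compound 1 to compound 3, at a place described in identical words. Because the step of a 2.9-fold higher number from compound 1 to compound 3 (0.46 log units; beyond the scatter) was a modest rise, a similar rise is expected for compound 4, namely a 2.7-fold higher number from compound 2 to compound 4 (0.42 log units; beyond the scatter). Compound 4 is estimated at 42000 nM, within 18000 nM to 95000 nM. One prior step is a thin basis, so the range is kept wide.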

Compound 4, half-maximal inhibitory concentration: 17700 nM
Estimate against measurement, compound 4: 2.4-fold (0.38 log units) above; measured number below the stated range.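

In this assay the change from hydroxy to methoxy gave a 1.1-fold higher number from compound 2 to compound 4 (0.05 log units; within the scatter) on the naphthalene-free wording of the shared amide series, and this step is the second reading of that change. These two readings do not show that the change behaves differently on the two cores, nor do they show that it carries over at a fixed size, and they set no size for a further core. The two steps stand side by side as follows: the same change on two cores in this assay, a 2.9-fold higher number (0.46 log units; beyond the scatter) from compound 1 to compound 3 and a 1.1-fold higher number (0.05 log units; within the scatter) from compound 2 to compound 4, 2.6-fold (0.41 log units) apart, within the scatter of two such steps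

Still open, as far as these compounds go, is what this assay reads when the hydroxy group gives way to an amine or a carboxylic acid. Also open, from the compounds shown here alone, is whether a longer chain on that oxygen, such as ethoxy, reads like methoxy.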